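Chain homologation in a carbamate-amide series: lipophilicity

The compounds below may be only part of what the source reports. "The series", "measured", "known", "first", "only" and "open" are said of these compounds alone.

Measured compounds:
compound 1, `CCCCCCNC(=O)Oc1ccc(Cl)cc1C(=O)Nc1cccc(Cl)c1`: 5.53
compound 2, `CCCCCCCNC(=O)Oc1ccc(Cl)cc1C(=O)Nc1cccc(Cl)c1`: 5.94
compound 3, `CCCCCCCCNC(=O)Oc1ccc(Cl)cc1C(=O)Nc1ccc(Cl)c(Cl)c1`: 6.92

In a physicochemical assay for lipophilicity (a lower number here means a more polar compound, a higher number a more lipophilic compound), compound 1 gives 5.53 and compound 2 gives 5.94. The two differ by methyl in place of hydrogen on a saturated chain carbon, six bonds along the chain from an amide-type nitrogen and the change brings a number 0.41 log units higher from compound 1 to compound 2 (beyond the scatter). Compound 3 gives 6.92, the highest of the three measured values; how its core differs from that of compound 1 is not broken down here.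

Compound 4, `CCCCCCCCCNC(=O)Oc1ccc(Cl)cc1C(=O)Nc1ccc(Cl)c(Cl)c1`, is not yet measured. It differs from compound 3 by methyl in place of hydrogen on a saturated chain carbon, eight bonds along the chain from an amide-type nitrogen. Among the compounds with values here, this is the same kind of change as the one from compound 1 to compound 2, not the same one: there the added carbon sits six bonds along the chain from the amide-type nitrogen, here eight bonds along the chain. Within the data shown here, because the first instance gave a number 0.41 log units higher from compound 1 to compound 2 (beyond the scatter), a step of similar size is expected here, a number 0.43 log units higher from compound 3 to compound 4 (beyond the scatter), with the reservation that only a single earlier instance is available and it sits on a different core. Compound 4 is thus estimated at 7.35, expected within 7 to 7.7.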

Compound 4, partition coefficient: 7.34
For compound 4 the middle estimate is 0.01 log units above the measured one, within the range that was stated.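

In this assay, methyl in place of hydrogen on a saturated chain carbon, eight bonds along the chain from an amide-type nitrogen, gives a number 0.42 log units higher from compound 3 to compound 4 (beyond the scatter) on the core of compound 3, while the same kind of change gave a number 0.41 log units higher from compound 1 to compound 2 (beyond the scatter) on the core of compound 1, and both steps are modest. This shows that the change carried across these two cores and these two chain places with a step of modest size each time, but it does not show that it will carry to other cores, and with core and chain place differing together, neither can be weighed separately from these two instances. No supporting evidence bears on why the step has this size.

The compounds shown leave open whether a step of this size continues with a longer chain than that of compound 4 in this assay on either core. They also leave open how a chain carrying an amine or a carboxylic acid would read in the same series.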